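A few compounds are considered here, and "the series" means these few. Any claim that something is new, unique, unknown or untested is made for them only; others in the source may bear on it.

Compound 2 `O=C(NCC1(O)CCCCCC1)c1cc(-c2ccc(Cl)cn2)ccc1Cl` gives 52 mL/min/kg in an in vitro ADME assay on microsomes from liver (Homo sapiens) for metabolic stability; a lower number here means slower removal, a higher number faster removal of the compound. Among the measured compounds shown here, its only neighbour, compound 1 `N#Cc1ccc(-c2ccc(Cl)c(C(=O)NCC3(O)CCCCCC3)c2)nc1`, gives 37 mL/min/kg in this assay; the step of a 1.4-fold higher number from compound 1 to compound 2 (0.15 log units; within the scatter) leaves the two within the scatter of each other, so compound 2 stands alongside compound 1 rather than apart from it. Compound 3 `Cc1cnc(-c2ccc(Cl)c(C(=O)NCC3(O)CCCCCC3)c2)cn1` carries 5-methylpyrazin-2-yl in place of 5-chloropyridin-2-yl on an aromatic carbon. For the measured compounds named here, the single measured step touches the same ring and stays within the scatter; on that basis no step beyond the scatter is expected, a 1.2-fold lower number from compound 2 to compound 3 (0.06 log units; within the scatter), while allowing that the whole ring changes here. Compound 3 is estimated at 45 mL/min/kg in this assay, with a range from 22 mL/min/kg to 90 mL/min/kg.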

Compound 3, clearance: 36 mL/min/kg
Beside the measured number, compound 3's estimate is 1.3-fold (0.10 log units) above it, and the stated range covers the measured number.
By their numbers in this assay, from the lowest: compounds 3, 1 and 2 (each within the scatter of the next).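

In this assay, the exchange at this position reaches the whole ring and not only its substituent: 5-methylpyrazin-2-yl in place of 5-chloropyridin-2-yl gives (a 1.4-fold lower number from compound 2 to compound 3 (0.16 log units; within the scatter)), and in place of 5-cyanopyridin-2-yl gives (a 1.0-fold lower number from compound 1 to compound 3 (0.01 log units; within the scatter)). All three compounds therefore lie within the scatter of one another, with chloro, cyano and methyl on the ring and one or two ring nitrogens. Nothing available accounts for these numbers.

On these data alone, whether an amine or a carboxylic acid on this ring would give a step beyond the scatter stays open. Also open, as far as these compounds go, is how a longer chain in place of the methyl would read.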